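The source may report more compounds than this note shows. Statements on the series, on what has been measured and on what is new or still open speak of the compounds shown alone.

Compound 1 `Cc1cccc(C[C@H]2C(=O)OC[C@@H]2Cc2ccccc2)c1`: 53000 nM
Compound 2 `Cc1ccc(C[C@H]2C(=O)OC[C@@H]2Cc2ccccc2)cc1`: 44000 nM

In a functional assay on HL-60 cells (Homo sapiens) for cytotoxicity, read by WST assay, with a stated time of 48 h (a lower number here means that less compound is needed, a higher number that more compound is needed for the effect), compound 2 gives 44000 nM, which stands within the scatter of compound 1. Compound 3 `O=C1OC[C@H](Cc2ccccc2)[C@H]1Cc1ccc(Cl)cc1` has chloro in place of methyl on an aromatic carbon. For the measured compounds named here, the only measured step nearby is a 1.2-fold lower number from compound 1 to compound 2 (0.08 log units; within the scatter), from 3-methylphenyl to 4-methylphenyl. It is small, but it does not exchange the methyl for anything else, so it is only a loose guide. No shift beyond the scatter is therefore expected. The estimated change is a 1.1-fold lower number from compound 2 to compound 3 (0.04 log units; within the scatter). Compound 3 is estimated at 40000 nM, with an expected range of 18000 nM to 80000 nM.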

Compound 3, half-maximal effective concentration: 36000 nM
Compound 3: the middle estimate sits 1.1-fold (0.05 log units) above what was measured; the range from low to high includes it.
By their numbers in this assay, from the lowest: compounds 3, 2 and 1 (each within the scatter of the next).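

In this assay, chloro in place of methyl on the aromatic carbon para to a large group gives a 1.2-fold lower number from compound 2 to compound 3 (0.09 log units; within the scatter) and so leaves the number within the scatter, which the two methyl compounds alone could not show for a change of the group itself. The step to the 4-chlorophenyl compound from the 3-methylphenyl compound, a 1.5-fold lower number from compound 1 to compound 3 (0.17 log units; within the scatter) as printed, also stays within the scatter. No evidence at hand bears on these steps. The compounds shown leave open whether an amine or a carboxylic acid at this position would move the number beyond the scatter.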